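This account rests on a few compounds, and the source may have more. Where it says the series, first, only, none or still open, it means among the compounds named here.

Of the compounds shown here, two built on a shared core have been tested in a functional assay on LM7 cells (Homo sapiens) for cytotoxicity, read by MTT assay, with a stated time of 72 h; on this read-out higher numbers stand for weaker inhibition and lower numbers for stronger inhibition. Compound 1, `Cc1nnc(SCc2cc(=O)c3cc(Cl)ccc3o2)o1`, carries a chlorine and a methyl oxadiazole. In this assay compound 1 gives > 25000 nM, a limit of the assay rather than a number. Compound 2, `Nc1nnc(SCc2cc(=O)c3ccccc3o2)s1`, carries an amino thiadiazole and no chlorine. In this assay compound 2 gives > 25000 nM, again a limit and not a number. Among the measured compounds shown here, both values sit at the limit of > 25000 nM in this assay, at which 2 of the 2 values shown sit, so compound 2 stands level with the only other compound known, and neither shows a measurable potency. Compound 3, `Nc1nnc(SCc2cc(=O)c3cc(Cl)ccc3o2)s1`, differs from compound 2 by chloro in place of hydrogen on an aromatic carbon, a chloro in place of hydrogen on an aromatic carbon. For the measured compounds named here, no measured pair shows what this swap does here, and compound 1, which also carries the chlorine, gave only a limit. The step from compound 2 to compound 3 is expected to be a step that the limit leaves unreadable from compound 2 to compound 3, nothing beyond the scatter. Compound 3 is therefore estimated at 30000 nM, within 12000 nM to 80000 nM, most likely reported once more only as a limit.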

Compound 3, half-maximal inhibitory concentration: > 25000 nM
Compound 3 ended at the assay's limit; the forecaster's own chance of this, stated with the estimate: 80%; the middle value is on the limit's open side.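

Compound 3 ends at the same limit as compound 1 and compound 2, so no step among these compounds can be read: the limit of > 25000 nM in this assay, at which 3 of the 3 values shown sit. The compounds shown leave open whether the chloro or the group on the sulfur changes potency at all in this assay.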